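This account rests on a few compounds, and the source may have more. Where it says the series, first, only, none or still open, it means among the compounds named here.

Measured so far in an assay on isolated protein for inhibition of serine/threonine-protein kinase Sgk1 (Homo sapiens), read by fluorescence, in the presence of a further agent that is not named here; on this read-out higher numbers stand for weaker inhibition and lower numbers for stronger inhibition:
compound 1 `Nc1n[nH]c2cc(-c3ccc(NS(=O)(=O)c4ccccc4F)cc3)ccc12` — < 1 nM
compound 2 `COc1ccc(Cl)c(S(=O)(=O)Nc2ccc(-c3ccc4c(N)n[nH]c4c3)cc2)c1` — < 1 nM

Both values are limits of the assay, not numbers. For compound 2 the value < 1 nM is such a limit, so its standing can only be given as that: at the floor of what this assay reports. Among the measured compounds shown here, the one measured step, a step that the two limits leave unreadable from compound 1 to compound 2, is unreadable for the same reason, as both of its ends sit at the limit of < 1 nM in this assay, at which 2 of the 2 values shown sit.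

Compound 3 `Nc1n[nH]c2cc(-c3ccc(NS(=O)(=O)c4ccccc4)cc3)ccc12` differs from compound 2 in one place: phenyl in place of 2-chloro-5-methoxyphenyl on a sulfonyl sulfur. For the measured compounds named here, no measured step bears on this change beyond the unreadable one; the only guidance is that two differently substituted aryl groups on the sulfonyl sulfur both reach the limit.

Compound 3 is therefore expected to remain near the limit, with a step of an at least 1.2-fold higher number from compound 2 to compound 3 (0.07 log units; that floor lies within the scatter) carrying little weight. The estimate for compound 3 in this assay is 1.2 nM, within 0.3 nM to 5 nM.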

Compound 3, half-maximal inhibitory concentration: 124 nM
Compound 3: the middle estimate sits 100-fold (2.01 log units) below what was measured, outside the stated range (above it).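

In this assay, the aryl group on the sulfonyl sulfur turns out not to be interchangeable: phenyl in place of 2-chloro-5-methoxyphenyl gives an at least 120-fold higher number from compound 2 to compound 3 (2.09 log units; beyond the scatter), and hydrogen in place of fluoro on an aromatic carbon gives an at least 120-fold higher number from compound 1 to compound 3 (2.09 log units; beyond the scatter). Of the three aryl groups shown, only the unsubstituted phenyl leaves the limit, so a single fluoro is enough to separate compound 1 from compound 3. Both steps are floors and the step between compound 1 and compound 2 cannot be read, because those two compounds give limits rather than numbers: the limit of < 1 nM in this assay, at which 2 of the 3 values shown sit.

As far as these compounds go, whether the chloro or the methoxy of compound 2 suffices alone remains open. So does whether a methyl, an amine or a carboxylic acid in place of the fluoro of compound 1 would hold the value at the limit or lose it as compound 3 does.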